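Swapping 2-hydroxyphenyl for 3-bromophenyl on the shared core

A few compounds are considered here, and "the series" means these few. Any claim that something is new, unique, unknown or untested is made for them only; others in the source may bear on it.

Measured so far in a functional assay on OVCAR-3 cells (Homo sapiens) for inhibition, read by MTT assay, with a stated time of 24 h; a lower number here means a stronger inhibitor, a higher number a weaker inhibitor:
compound 1 `CC1(C)[C@H]2CC[C@]1(C)N(Cc1cn(-c3ccccc3Cl)nn1)C(=O)C2` gives 40 nM
compound 2 `CC1(C)[C@H]2CC[C@]1(C)N(Cc1cn(-c3ccccc3O)nn1)C(=O)C2` gives 90 nM

Of these two, compound 2 carries the higher number, which makes it the weaker inhibitor, and compound 1 is its nearest neighbour. For the measured compounds named here, the only measured step is a 2.3-fold higher number from compound 1 to compound 2 (0.35 log units; beyond the scatter), with hydroxy in place of chloro on an aromatic carbon.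

Compound 3 `CC1(C)[C@H]2CC[C@]1(C)N(Cc1cn(-c3cccc(Br)c3)nn1)C(=O)C2` has not yet been measured. It has 3-bromophenyl in place of 2-hydroxyphenyl on an aromatic nitrogen, and the counted difference is 3-bromophenyl in place of 2-hydroxyphenyl on an aromatic nitrogen.

The measured step bears on this change only in part. Going by the values given here, compound 3, like compound 1 at 40 nM, has a halogen-bearing phenyl and no hydroxy, but its halogen and the name of its group differ, and no measured step covers that difference. A modest move toward a lower number is therefore expected, close in size to the measured step. In this assay the expected change is a 2.3-fold lower number from compound 2 to compound 3 (0.35 log units; beyond the scatter) on this estimate. Compound 3 is estimated at 40 nM, with an expected range from 13 nM to 120 nM in this read-out.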

Compound 3, half-maximal inhibitory concentration: 30 nM
Beside the measured number, compound 3's estimate is 1.3-fold (0.12 log units) above it; measured number inside the range.
By their numbers in this assay, from the lowest: compounds 3 and 1 (each within the scatter of the next); then compound 2.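

In this assay, the step from 2-hydroxyphenyl to 3-bromophenyl on the aromatic nitrogen is a 3.0-fold lower number from compound 2 to compound 3 (0.48 log units; beyond the scatter), so this position accepts a halogen-bearing phenyl placed differently from the chloro group of compound 1 without a loss against compound 2. The comparison with the chlorinated analogue is a 1.3-fold lower number from compound 1 to compound 3 (0.12 log units; within the scatter): 2-chlorophenyl and 3-bromophenyl differ in both the halogen and its place on the phenyl, yet their numbers cannot be told apart, which leaves compound 2, the only one of the three with a hydroxy group, as the weakest inhibitor. Nothing shown here explains these differences in the cell read-out.

Since compound 3 changes the halogen and its place together, the compounds shown cannot separate the two, and a 2-bromophenyl or 3-chlorophenyl group would be needed to do so. They also leave open how a 3-hydroxyphenyl group, an unsubstituted phenyl, or a phenyl bearing an amine or a carboxylic acid would read at this position.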